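Hydroxyphenyl position and alpha-glucosidase inhibition in two scaffolds

The source may hold more compounds than are shown below. What is called first, only, known or untested is meant among the compounds shown, and "the series" means these compounds.

Of the compounds shown here, three have been measured in an assay on isolated protein for inhibition of Alpha glucosidase (Homo sapiens), with stated times of 5 min and 15 min, tested at 50 uM; a lower number here means less inhibition, a higher number more inhibition at the concentration tested (going by the name of the read-out). Compound 1 `O=C(C1=C(O)/C(=C/c2ccc(O)cc2)CCC1)c1ccccc1` gives 34.9%. Compound 2 `O=C(/C=C(O)/C=C/c1ccc(O)cc1)c1ccccc1O` gives 20.4%, and compound 3 `O=C(/C=C(O)/C=C/c1cccc(O)c1)c1ccccc1O` gives 40.4%. The step of a number 20 percentage points higher from compound 2 to compound 3 (beyond the scatter) follows the change (3-hydroxyphenyl in place of 4-hydroxyphenyl on a double-bonded chain carbon bound to a double-bonded chain carbon). Compound 1 and compound 2 carry different cores; how the two cores differ is not broken down here, and the values only show that compound 1 sits above compound 2 in this assay by a step beyond the scatter, while compound 1 and compound 3 lie within the scatter of each other.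

Compound 4 `O=C(C1=C(O)/C(=C/c2cccc(O)c2)CCC1)c1ccccc1` is not yet measured. It is related to compound 1 by the change (3-hydroxyphenyl in place of 4-hydroxyphenyl on a double-bonded chain carbon bound to a double-bonded ring carbon). For the measured compounds named here, this is the same kind of change as the one from compound 2 to compound 3, not the same change: in one case the substituent sits on a double-bonded chain carbon bound to a double-bonded chain carbon, in the other on a double-bonded chain carbon bound to a double-bonded ring carbon.

Going by the values given here, because the only measured precedent is a number 20 percentage points higher from compound 2 to compound 3 (beyond the scatter), the step of a number 13.1 percentage points higher from compound 1 to compound 4 (beyond the scatter) is expected, a little smaller than the earlier one since the surroundings of the place differ. On this basis compound 4 is estimated at 48% in this assay, with a range from 32% to 64% expected.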

Compound 4, a percentage reported as inhibition, at one concentration (the size of the read-out at that concentration, not a potency): 43.2%
Estimate against measurement, compound 4: 4.8 percentage points above; low and high end bracket the measured number.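

In this assay, 3-hydroxyphenyl in place of 4-hydroxyphenyl on a double-bonded chain carbon bound to a double-bonded ring carbon gives a number 8.3 percentage points higher from compound 1 to compound 4 (within the scatter), so on the core of compound 1 this step alone cannot be told apart from no change. Set beside the step on the other core, it does not differ from it by more than the scatter allows: the same change on two cores in this assay, a number 20 percentage points higher (beyond the scatter) from compound 2 to compound 3 and a number 8.3 percentage points higher (within the scatter) from compound 1 to compound 4, 11.7 percentage points apart, within the scatter of two such steps. For the compounds shown here, the two pairs are therefore compatible with a step of similar size on both cores, but they do not establish that the change carries over, since only one of the two steps lies beyond the scatter and both rest on percentages at a single concentration, which are not potencies.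

Still open, as far as these compounds go, is whether a methoxy group or a carboxylic acid in place of the hydroxyl on the phenyl ring, or a second hydroxyl on that ring, would behave alike on the two cores. Also open, from the compounds shown here alone, is whether the relation between the 3-hydroxyphenyl and 4-hydroxyphenyl compounds holds across a range of concentrations, and whether it extends to any core beyond these two.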